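A few compounds are considered here, and "the series" means these few. Any claim that something is new, unique, unknown or untested is made for them only; others in the source may bear on it.

Among the compounds with values here, compound 1 `CCCCN1C(=O)CCN(S(=O)(=O)c2ccc(-n3nc(C(=O)O)cc3C)cc2)C1=S` gives 2% in a functional assay on the whole organism (blood, strain albino) with Mus musculus as the target, with stated times of 6 days and 3 h, at a dose of 1 mmol/kg by the oral route (on this read-out higher numbers stand for more inhibition at the one dose given (going by the name of the read-out) and lower numbers for less inhibition), the second highest of the three numbers measured so far. Compound 2 `CCCCN1C(=O)CCN(S(=O)(=O)c2ccc(-n3nc(C)cc3C)cc2)C1=S` gives 1% in this assay, and the two sit within the scatter: a number 1 percentage points lower from compound 1 to compound 2 (within the scatter). Compound 3 `Cc1cc(C)n(-c2ccc(S(=O)(=O)N3CCC(=O)N(Cc4ccccc4)C3=S)cc2)n1` gives 18% in this assay, and the exchange at the saturated chain carbon bound to the amide-type nitrogen in the ring was a number 17 percentage points higher from compound 2 to compound 3 (beyond the scatter). Compound 4 `C=CCN1C(=O)CCN(S(=O)(=O)c2ccc(-n3nc(C(=O)O)cc3C)cc2)C1=S` differs from compound 1 at that same place: vinyl in place of propyl on a saturated chain carbon bound to an amide-type nitrogen in a ring. Within the data shown here, only the step from compound 2 to compound 3 bears on this position, and it brought in an aromatic ring, which vinyl does not; no measured step exchanges one chain for another. The step is therefore expected to be a number 2 percentage points higher from compound 1 to compound 4 (within the scatter). Compound 4 is estimated at 4%, between -6% and 15%.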

Compound 4, a percentage reported as inhibition, in the whole organism at one dose (the size of the read-out at that dose, not a potency): 0%
Estimate against measurement, compound 4: 4 percentage points above, and the stated range covers the measured number.
By their numbers in this assay, from the lowest: compounds 4, 2 and 1 (each within the scatter of the next); then compound 3.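

This step exchanges one chain for another on a saturated chain carbon bound to an amide-type nitrogen in a ring, and in this assay it gives a number 2 percentage points lower from compound 1 to compound 4 (within the scatter). Butyl to allyl therefore stands apart from the only step beyond the scatter at this place, a number 17 percentage points higher from compound 2 to compound 3 (beyond the scatter), which brought in phenyl. Nothing measured here bears on the reason for this result. From the compounds shown here alone, whether phenyl would give a similar step alongside the carboxy group stays open, as does the outcome with a longer chain or an amine at this place.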